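The source may hold more compounds than are shown below. What is called first, only, known or untested is meant among the compounds shown, and "the series" means these compounds.

Among the measured compounds shown here, compound 3 `CN(C)CCn1cnnc1-c1cc(Oc2ccc(NC(=O)N/N=C/c3cccc(Br)c3)cc2F)ccn1` gives 450 nM in a functional assay on MKN-45 cells (Homo sapiens) for cytotoxicity, read by MTT assay, with a stated time of 72 h (a higher number here means a weaker inhibitor, a lower number a stronger inhibitor), the lowest of the three numbers measured so far. Compound 1 `COc1ccc(/C=N/NC(=O)Nc2ccc(Oc3ccnc(-c4nncn4CCN(C)C)c3)c(F)c2)c(OC)c1` gives 1680 nM in this assay, and compound 2 `CN(C)CCn1cnnc1-c1cc(Oc2ccc(NC(=O)N/N=C/c3ccccc3O[N+](=O)[O-])cc2F)ccn1` gives 1020 nM in this assay. Both steps toward compound 3 lower the number: a 3.7-fold lower number from compound 1 to compound 3 (0.57 log units; beyond the scatter) and a 2.3-fold lower number from compound 2 to compound 3 (0.36 log units; beyond the scatter), whereas a 1.6-fold lower number from compound 1 to compound 2 (0.22 log units; within the scatter).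

Compound 4 `CN(C)CCn1cnnc1-c1cc(Oc2ccc(NC(=O)N/N=C/c3ccc(O)c(F)c3)cc2F)ccn1` differs from compound 3 in one place: 3-fluoro-4-hydroxyphenyl in place of 3-bromophenyl on a carbon with a double bond to nitrogen. For the measured compounds named here, no measured pair swaps a bromine on this phenyl ring for a hydroxyl together with a fluorine, so the measured steps bear on the change only indirectly. What they do show is that the 3-bromophenyl of compound 3 gave the lowest number of the three aryl groups tried, and that each of the other two aryl groups, read through a 3.7-fold lower number from compound 1 to compound 3 (0.57 log units; beyond the scatter) and a 2.3-fold lower number from compound 2 to compound 3 (0.36 log units; beyond the scatter) in reverse, came with a higher number. Compound 3 sits at 450 nM and the two other aryl groups gave higher numbers, so the expectation leans toward a rise. Compound 4 is therefore expected to show a modest rise in this assay, a 2.0-fold higher number from compound 3 to compound 4 (0.30 log units; within the scatter). The estimate for compound 4 in this assay is 900 nM, with a range from 400 nM to 2000 nM.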

Compound 4, half-maximal inhibitory concentration: 1970 nM
For compound 4 the middle estimate is 2.2-fold (0.34 log units) below the measured one, within the range that was stated.
By their numbers in this assay, from the lowest: compound 3; then compounds 2, 1 and 4 (each within the scatter of the next).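

In (this assay), putting 3-fluoro-4-hydroxyphenyl in place of 3-bromophenyl on a carbon with a double bond to nitrogen gives the largest step yet seen at this position, with a 4.4-fold higher number from compound 3 to compound 4 (0.64 log units; beyond the scatter) as its size. Among the compounds shown here, compound 4 cannot be told apart from the other two aryl compounds, given a 1.9-fold higher number from compound 2 to compound 4 (0.29 log units; within the scatter) and a 1.2-fold higher number from compound 1 to compound 4 (0.07 log units; within the scatter), and with a 1.6-fold lower number from compound 1 to compound 2 (0.22 log units; within the scatter) these three form one group, leaving the 3-bromophenyl of compound 3 as the only aryl group here that stands apart. The entering group adds a hydrogen-bond donor and a hydrogen-bond acceptor that 3-bromophenyl lacks, but nothing available explains the difference in numbers.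

The compounds shown leave open whether the lower number of compound 3 goes with the bromine itself, a question that a 3-chlorophenyl or 3-methylphenyl group would help to settle. They also leave open whether the hydroxyl or the fluorine of 3-fluoro-4-hydroxyphenyl goes with the higher number, which a 4-hydroxyphenyl or 3-fluorophenyl group would separate.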